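The source may hold more compounds than are shown below. What is called first, only, known or untested is meant among the compounds shown, and "the series" means these compounds.

Measured so far:
- Compound 1 `CC(C)CSc1nc(N)nc2c1ncn2/C=C1/CC1(CO)CO`: > 20000 nM
- Compound 2 `C=CCOc1nc(N)nc2c1ncn2/C=C1/CC1(CO)CO`: > 20000 nM

In an ADME assay on Akata cells (Homo sapiens) for cytotoxicity, with a stated time of 7 days (on this read-out lower numbers stand for higher toxicity in this test and higher numbers for lower toxicity in this test), compound 2 gives > 20000 nM, which is a limit and not a number. Compound 1 gives > 20000 nM, also a limit. Neither compound therefore has a measured value, and the record shows (the limit of > 20000 nM in this assay, at which 2 of the 2 values shown sit).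

Compound 3 `COCCOc1nc(N)nc2c1ncn2/C=C1/CC1(CO)CO` differs from compound 2 as follows: methoxymethyl in place of vinyl on a saturated chain carbon bound to an oxygen on an aromatic ring. In words, this is methoxymethyl in place of vinyl on a saturated chain carbon bound to an oxygen on an aromatic ring, or allyloxy to 2-methoxyethoxy.

Within the data shown here, the only measured step that bears on this change is a step that the two limits leave unreadable from compound 1 to compound 2, with allyloxy in place of isobutylsulfanyl on an aromatic carbon. It gives no size to carry over, so no step beyond the scatter is expected in this assay. The expected result is a step that the limit leaves unreadable from compound 2 to compound 3. A limit is again the likeliest report. For compound 3 the estimate is 25000 nM, with an expected range from 10000 nM to 60000 nM.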

Compound 3, half-maximal cytotoxic concentration: > 20000 nM
Compound 3 ended at the assay's limit (the forecaster's own chance of this, stated with the estimate: 85%); the middle value does not contradict the limit.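

No new step can be read among compound 1, compound 2 and compound 3 in this assay, as each result is a limit and not a number: the limit of > 20000 nM in this assay, at which 3 of the 3 values shown sit.

The compounds shown leave open whether the isobutylsulfanyl, allyloxy and 2-methoxyethoxy compounds differ at all in this assay, and by how much.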